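Benzyl variation in a piperazine series: toward compound 3

The compounds below may be only part of what the source reports. "The series", "measured", "known", "first", "only" and "open" are said of these compounds alone.

Compound 1 `CCOC(=O)c1cnc(N2CCN(Cc3ccc(C#N)cc3)CC2)nc1Oc1c(C)cc(-c2ccc(C#N)cc2)cc1C` is the reference of the pair measured so far. In an ADME assay on MT4 cells (Homo sapiens) for cytotoxicity, read by MTT assay, with a stated time of 4 days (on this read-out higher numbers stand for lower toxicity in this test and lower numbers for higher toxicity in this test), compound 1 reaches only the assay limit > 125000 nM. Compound 2 `CCOC(=O)c1cnc(N2CCN(Cc3ccccc3F)CC2)nc1Oc1c(C)cc(-c2ccc(C#N)cc2)cc1C` carries a 2-fluorophenyl on a saturated chain carbon bound to an amine nitrogen in a ring. In this assay compound 2 likewise reaches only the limit > 125000 nM. The step that the two limits leave unreadable from compound 1 to compound 2 therefore cannot be sized, both values sitting at the limit of > 125000 nM in this assay, at which 2 of the 2 values shown sit. Compound 3 `CCOC(=O)c1cnc(N2CCN(Cc3cccc(OC)c3)CC2)nc1Oc1c(C)cc(-c2ccc(C#N)cc2)cc1C` differs from compound 2 by 3-methoxyphenyl in place of 2-fluorophenyl on a saturated chain carbon bound to an amine nitrogen in a ring. No readable step bears on this change, so compound 3 is expected to stay at the limit, estimated at 125000 nM with a range from 60000 nM to 300000 nM. The step this estimate implies, a number no higher from compound 2 to compound 3 (the limit leaves the size open), is expected to be none beyond the scatter.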

Compound 3, half-maximal cytotoxic concentration: > 125000 nM
Compound 3: no number, only a limit; the forecaster's own chance of this, stated with the estimate: 80%; the middle value lies on the limit itself.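

In this assay no step among compound 1, compound 2 and compound 3 can be read, since all three values are limits: the limit of > 125000 nM in this assay, at which 3 of the 3 values shown sit.

The compounds shown leave open at what concentration any of the three becomes cytotoxic, and whether the benzyl changes shift that concentration.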